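Methoxy to methylsulfonyl on the pyridyl core

The source may report more compounds than this note shows. Statements on the series, on what has been measured and on what is new or still open speak of the compounds shown alone.

Compound 1 `CCC(CC)CNc1c(C(N)=O)cnc2ccc(-c3ccc(COC)cc3)cc12` and compound 2 `CCC(CC)CNc1c(C(N)=O)cnc2ccc(-c3ccc(CS(C)(=O)=O)cc3)cc12` share one core; compound 3 `CCC(CC)CNc1c(C(N)=O)cnc2ccc(-c3ccc(COC)nc3)cc12` and compound 4 `CCC(CC)CNc1c(C(N)=O)cnc2ccc(-c3ccc(CS(C)(=O)=O)nc3)cc12` share another. The two cores differ as counted in 6-(methoxymethyl)pyridin-3-yl in place of 4-(methoxymethyl)phenyl on an aromatic carbon. In a physicochemical assay for lipophilicity, using the shake flask method, measured as octanol-water partition, at pH 7.4 (a higher number here means a more lipophilic compound, a lower number a more polar compound), compound 1 gives 4.1. Compound 2 gives 3.5 in this assay. For compound 3 this assay reports only a limit, > 4.3. The step of a number at least 0.20 log units higher from compound 1 to compound 3 (that floor lies within the scatter) therefore rests on that limit, see (the limit of > 4.3 in this assay, at which 1 of the 3 values shown sits).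

The change from compound 1 to compound 2 is methylsulfonyl in place of methoxy on a saturated chain carbon bound to an aromatic carbon, and it made the step of a number 0.60 log units lower from compound 1 to compound 2 (beyond the scatter). The change from compound 3 to compound 4 is methylsulfonyl in place of methoxy on a saturated chain carbon bound to an aromatic carbon, the same change at the same place. A step of about the same size is expected, a number at least 0.40 log units lower from compound 3 to compound 4 (beyond the scatter), resting on a number 0.60 log units lower from compound 1 to compound 2 (beyond the scatter). Compound 4 is expected at 3.9, between 3.5 and 4.4.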

Compound 4, distribution coefficient: 3.1
Compound 4: the middle estimate sits 0.80 log units above what was measured; the measured number lies below the stated range.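

Moving from methoxy to methylsulfonyl on a saturated chain carbon bound to an aromatic carbon gives a lower number in this assay on both cores, with a number 0.60 log units lower from compound 1 to compound 2 (beyond the scatter) and a number at least 1.20 log units lower from compound 3 to compound 4 (beyond the scatter), so the direction carries across this one pair of cores. From the compounds shown here alone, the reading for compound 3, > 4.3, is a limit and not a number, so the second step is only a floor and its full size stays unknown: the limit of > 4.3 in this assay, at which 1 of the 4 values shown sits. Two pairs do not make a general rule, and they do not show why the step is large on one core and modest on the other.

Going by these compounds, it remains open how an amine or a carboxylic acid in place of methylsulfonyl would read on these two cores. On these data alone, whether the same direction holds on any further core also remains open.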